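The compounds below may be only part of what the source reports. "The series", "measured", "known", "first", "only" and "open" are said of these compounds alone.

Compound 1 `c1ccc([C@@H]2C[C@@H]3Cc4ccc5ccccc5c4N2O3)cc1`: in an ADME assay on THP-1 cells (Homo sapiens) for cytotoxicity, read by MTT assay, with a stated time of 72 h (a higher number here means that more compound is tolerated, a lower number that less compound is tolerated), compound 1 gives > 350000 nM, which is a limit of the assay.
Compound 2 `Clc1cccc([C@@H]2C[C@@H]3Cc4ccc5ccccc5c4N2O3)c1`: in this assay compound 2 gives > 300000 nM, also a limit.
Compound 3 `Brc1cccc([C@@H]2C[C@@H]3Cc4ccc5ccccc5c4N2O3)c1`: in this assay compound 3 gives > 250000 nM, again a limit.

Compound 3 therefore stands only at a limit, as do the other two, and its place among them cannot be read. Compound 4 `COc1cccc([C@@H]2C[C@@H]3Cc4ccc5ccccc5c4N2O3)c1` differs from compound 3 by methoxy in place of bromo on an aromatic carbon. The steps that touch the same place are a step that the two limits leave unreadable from compound 1 to compound 3, a step that the two limits leave unreadable from compound 2 to compound 3 and a step that the two limits leave unreadable from compound 1 to compound 2; none of them can be sized, because every value sits at a limit (the limit of > 250000 nM in this assay, at which 1 of the 3 values shown sits, (the limit of > 300000 nM in this assay, at which 1 of the 3 values shown sits), (the limit of > 350000 nM in this assay, at which 1 of the 3 values shown sits)). The step that the limit leaves unreadable from compound 3 to compound 4 is thus expected to show nothing beyond the scatter. Compound 4 is expected to give 300000 nM in this assay, between 100000 nM and 500000 nM, most likely again reported only as a limit.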

Compound 4, half-maximal cytotoxic concentration: > 300000 nM
Compound 4: only a limit was reported; the forecaster's own chance of this, stated with the estimate: 85%; the middle value sits exactly at the limit.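

Compound 4 gives only a limit in this assay, as do compound 1, compound 2 and compound 3, so none of the steps to compound 4 can be read. Going by these compounds, what stays open is the concentration at which any of these four compounds harms the cells, and whether hydrogen, chloro, bromo or methoxy at this place makes any difference.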